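A few compounds are considered here, and "the series" means these few. Any claim that something is new, unique, unknown or untested is made for them only; others in the source may bear on it.

Measured so far:
compound 1 `Cc1cncc(CNC(=O)Nc2ccc(S(=O)(=O)c3ccccc3)cc2)c1` — 144 nM
compound 2 `C[C@@H]1CN(S(=O)(=O)c2ccc(NC(=O)NCc3cccnc3)cc2)C[C@H](C)O1` — 15 nM

In a functional assay on A2780 cells (Homo sapiens) for antiproliferative activity, read by sulforhodamine B assay, with a stated time of 72 h (on this read-out lower numbers stand for stronger inhibition and higher numbers for weaker inhibition), compound 2 gives 15 nM, the lowest of the two numbers. Compound 1 gives 144 nM in this assay, a gap beyond the usual scatter. Compound 3 `O=C(NCc1cccnc1)Nc1ccc(S(=O)(=O)N[C@H]2CC[C@H](O)CC2)cc1` awaits measurement; it differs from compound 2 by (4-hydroxycyclohexyl)amino in place of 2,6-dimethylmorpholin-4-yl on a sulfonyl sulfur. Going by the values given here, no step between measured compounds touches the sulfonyl sulfur, so the size of this step is uncertain; a modest rise in the number is expected, possibly beyond the scatter, with no strong loss anticipated. Compound 3 is expected at 40 nM in this assay. The likely range for compound 3 runs from 10 nM to 160 nM. The expected step is a 2.7-fold higher number from compound 2 to compound 3 (0.43 log units; beyond the scatter).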

Compound 3, half-maximal inhibitory concentration: 369 nM
The estimate for compound 3 lay 9.2-fold (0.96 log units) below the measured number, and the stated range ends below it.
By their numbers in this assay, from the lowest: compound 2; then compound 1; then compound 3.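

In this assay the sulfonyl sulfur proves sensitive to its substituent: replacing 2,6-dimethylmorpholin-4-yl with (4-hydroxycyclohexyl)amino gives a 25-fold higher number from compound 2 to compound 3 (1.39 log units; beyond the scatter) even though the two groups hold the same atoms. The change therefore lies in how those atoms are joined, with a carbon-only ring and added hydrogen-bond donors in the entering group. Nothing at hand accounts for the size of this step.

Still open, going by these compounds, is whether the loss follows the hydroxyl, the amino hydrogen or the ring itself. Cyclohexylamino or unsubstituted morpholin-4-yl on the sulfonyl sulfur would help separate these.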